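This account rests on a few compounds, and the source may have more. Where it says the series, first, only, none or still open, it means among the compounds named here.

Compound 3 `COc1ccc(Cc2cc(-c3ccc(OC)cc3)nn(CC(=O)Nc3ccc(Br)cc3)c2=O)cc1` is one of three compounds examined in a functional assay on HL-60 cells (Homo sapiens), read by calcium flux; on this read-out lower numbers stand for an effect already at smaller amounts and higher numbers for an effect only at larger amounts of compound. In this assay compound 3 gives only a limit, > 50000 nM, not a number. Compound 1 `COc1ccc(Cc2cc(-c3cccs3)nn(CC(=O)Nc3ccc(Br)cc3)c2=O)cc1` likewise stops at a limit, > 50000 nM. Compound 2 `COc1cccc(Cc2cc(-c3cccs3)nn(CC(=O)Nc3ccc(F)cc3)c2=O)c1` also stops at a limit, > 50000 nM. All values therefore sit at the limit of > 50000 nM in this assay, at which 3 of the 3 values shown sit. The new compound 4 `COc1ccc(Cc2cc(-c3ccc(C)cc3)nn(CC(=O)Nc3ccc(Br)cc3)c2=O)cc1` differs from compound 3 by methyl in place of methoxy on an aromatic carbon. Among the compounds with values here, the only measured step nearby, a step that the two limits leave unreadable from compound 1 to compound 3, has limits at both ends, so its size stays unreadable. Within the data shown here, no measured step touches methyl against methoxy at all. Compound 4 is thus expected to stay near the same limit, estimated at 50000 nM, between 15000 nM and 200000 nM. The expected step, a number no higher from compound 3 to compound 4 (the limit leaves the size open), is therefore none beyond the scatter.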

Compound 4, half-maximal effective concentration: > 50000 nM
Compound 4: a limit, no number; the forecaster's own chance of this, stated with the estimate: 80%; the middle value lies on the limit itself.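

Compound 4 stops at a limit, as do compound 3 and compound 1, so the steps from compound 3 and from compound 1 to compound 4 cannot be read. The compounds shown leave open which change, if any, would give an actual number in this assay.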